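One added methoxy group on compound 3

The source may hold more compounds than are shown below. What is called first, only, known or untested is meant among the compounds shown, and "the series" means these compounds.

Of the compounds shown here, three have been tested in an ADME assay on BJ cells (Homo sapiens) for cytotoxicity, read by MTT assay, with a stated time of 72 h (a higher number here means a weaker inhibitor, a lower number a stronger inhibitor), and none of them gives a number. Compound 1 `COc1ccc(CNc2ncnc3c2ncn3C2CCCCO2)c(OC)c1OC` reads > 37500 nM, which is a limit of the assay. Compound 2 `COc1ccc(CNc2ncnc3c2ncn3C2CCCO2)cc1OC` reads > 100000 nM, also a limit. Compound 3 `COc1ccc(CNc2ncnc3c2ncn3C2CCCO2)c(OC)c1` reads > 100000 nM, likewise a limit, so it sits at the limit of > 100000 nM in this assay, at which 2 of the 3 values shown sit.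

Compound 4 `COc1ccc(CNc2ncnc3c2ncn3C2CCCO2)c(OC)c1OC` has not yet been measured. It derives from compound 3 by methoxy in place of hydrogen on an aromatic carbon, (methoxy in place of hydrogen on an aromatic carbon). For the measured compounds named here, no step between measured compounds is available to size this change, so no shift beyond the scatter is expected in this assay, in either direction. This expectation rests on compound 3 and its limit of > 100000 nM. The estimated change is a number no higher from compound 3 to compound 4 (the limit leaves the size open), which is expected to stay small. For compound 4 the estimated value is 100000 nM, with an expected range from 40000 nM to 200000 nM. The most likely report is again a limit rather than a number.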

Compound 4, half-maximal inhibitory concentration: > 100000 nM
Compound 4: only a limit was reported (the forecaster's own chance of this, stated with the estimate: 85%); the middle value sits exactly at the limit.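

In this assay, for the compounds shown here, compound 4 gives only a limit, as do compound 1, compound 2 and compound 3, so no step to compound 4 can be read from any of them. The compounds shown leave open how much methoxy in place of hydrogen, or oxolan-2-yl in place of oxan-2-yl, changes the reading.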